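A few compounds are considered here, and "the series" means these few. Any claim that something is new, unique, unknown or untested is made for them only; others in the source may bear on it.

Three compounds share one core, in which an anilino group sits on a thiazole-type ring bearing a ketone linked through a double bond to a second aromatic ring. Compound 1 `COc1cccc(/C=C/C(=O)c2sc(Nc3ccccc3)nc2C)c1` carries a 3-methoxyphenyl on that chain; in a functional assay on BGC-823 cells (Homo sapiens) for cytotoxicity, read by MTT assay (on this read-out lower numbers stand for stronger inhibition and higher numbers for weaker inhibition), compound 1 gives 14300 nM. Compound 3 `Cc1nc(Nc2ccccc2)sc1C(=O)/C=C/c1ccccc1Cl` carries a 2-chlorophenyl there, and in this assay compound 3 gives 22800 nM. Compound 2 `Cc1nc(Nc2ccccc2)sc1C(=O)/C=C/c1ccc(Cl)cc1` carries a 4-chlorophenyl. For compound 2 in this assay only a limit is reported, > 25000 nM, which is the limit of > 25000 nM in this assay, at which 1 of the 3 values shown sits. The steps of an at least 1.7-fold higher number from compound 1 to compound 2 (0.24 log units; that floor lies within the scatter), a 1.6-fold higher number from compound 1 to compound 3 (0.20 log units; within the scatter) and an at least 1.0-fold lower number from compound 2 to compound 3 (0.04 log units; that floor lies within the scatter) all stay within the usual scatter, so no measured change of the chain aryl moves the number clearly.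

Compound 4 `Cc1cccc(Nc2nc(C)c(C(=O)/C=C/c3ccc(Cl)cc3)s2)c1` differs from compound 2 by methyl in place of hydrogen on an aromatic carbon. Among the measured compounds shown here, none of the measured steps touches the anilino ring, so no measured step bears directly on this change. Compound 4 is therefore expected near compound 2, at 30000 nM with a range from 12000 nM to 80000 nM, meaning an expected step that the limit leaves unreadable from compound 2 to compound 4.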

Compound 4, half-maximal inhibitory concentration: > 25000 nM
Compound 4: no number, only a limit (the forecaster's own chance of this, stated with the estimate: 55%); the middle value lies beyond the limit too.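

In this assay compound 2 and compound 4 both give only a limit and not a number, so no step between them can be read: the limit of > 25000 nM in this assay, at which 2 of the 4 values shown sit.

The compounds shown leave open whether methyl in place of hydrogen on the anilino ring changes the number at all.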